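Aryl ketone variation on a shared triazolothiadiazine core

The source may report more compounds than this note shows. Statements on the series, on what has been measured and on what is new or still open speak of the compounds shown alone.

Measured so far:
compound 1 `COc1cc(-c2nnc3n2NC(c2ccco2)C(C(=O)c2ccccc2)S3)cc(OC)c1OC`, 39800 nM
compound 2 `COc1cc(-c2nnc3n2NC(c2ccco2)C(C(=O)c2ccc(C(F)(F)F)cc2)S3)cc(OC)c1OC`, 33600 nM

Both values come from a functional assay on MCF7 cells (Homo sapiens) for cytotoxicity, read by MTT assay, with a stated time of 48 h; a higher number here means a weaker inhibitor, a lower number a stronger inhibitor. For the measured compounds named here, compound 1 gives 39800 nM and compound 2 gives 33600 nM; compound 2 has the lowest of the two numbers, yet the one measured step, a 1.2-fold lower number from compound 1 to compound 2 (0.07 log units; within the scatter), lies within the scatter, so the two compounds are not distinguished by this assay.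

Compound 3 `COc1cccc(C(=O)C2Sc3nnc(-c4cc(OC)c(OC)c(OC)c4)n3NC2c2ccco2)c1` is the next member and is not yet measured. It differs from compound 2 in the aryl ketone part: 3-methoxyphenyl in place of 4-(trifluoromethyl)phenyl on a carbonyl carbon.

Going by the values given here, only one measured step touches this part of the molecule, the exchange of hydrogen for trifluoromethyl on the ketone aryl ring, and it gave a 1.2-fold lower number from compound 1 to compound 2 (0.07 log units; within the scatter), a step within the scatter. Nothing measured in the series speaks for a change of the aryl group at this position moving the number beyond the scatter, so no step beyond the scatter is expected for compound 3, in either direction.

Compound 3 is therefore estimated at 36000 nM in this assay, with a range of 12000 nM to 100000 nM, which corresponds to an expected step of a 1.1-fold higher number from compound 2 to compound 3 (0.03 log units; within the scatter).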

Compound 3, half-maximal inhibitory concentration: > 100000 nM
Compound 3: only a limit was reported (the forecaster's own chance of this, stated with the estimate: 15%); at least 2.7-fold (0.44 log units) between middle value and limit.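

In this assay compound 3 gives > 100000 nM as a limit and not as a number. The ketone aryl group now proves able to move the result beyond the scatter, something the exchange of hydrogen for trifluoromethyl did not show, with a 1.2-fold lower number from compound 1 to compound 2 (0.07 log units; within the scatter) staying within it. The change to 3-methoxyphenyl gives an at least 2.9-fold higher number from compound 2 to compound 3 (0.47 log units; beyond the scatter) and, read from the unsubstituted phenyl ketone as methoxy in place of hydrogen on an aromatic carbon, it gives an at least 2.5-fold higher number from compound 1 to compound 3 (0.40 log units; beyond the scatter) so both comparisons point the same way, with the full size of each step unknown: the limit of > 100000 nM in this assay, at which 1 of the 3 values shown sits.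

The compounds shown leave open whether this step belongs to the methoxy group as such or to its place on the ring, and whether an amine or a carboxylic acid on the same aryl ring would also reach the limit. They also leave open whether any aryl group on this carbonyl carbon can bring the number clearly below those of compound 1 and compound 2, which are not distinguished from each other.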